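Thiophen-2-yl for furylethenyl: series flat so far

A few compounds are considered here, and "the series" means these few. Any claim that something is new, unique, unknown or untested is made for them only; others in the source may bear on it.

In a functional assay on SK-MEL-2 cells (Homo sapiens) for antiproliferative activity (a higher number here means that more compound is needed for the effect, a lower number that less compound is needed), compound 3 `C(=C/c1ccco1)\c1cc(-c2ccco2)cc(-c2cccs2)n1` gives 118000 nM. Compound 1 `c1coc(-c2ccnc(-c3cccs3)c2)c1` gives 118000 nM and compound 2 `c1ccc(-c2cc(-c3cccs3)nc(-c3cccs3)c2)nc1` gives 118000 nM; compound 3 stands level with both within the scatter, no order among them. Compound 4 `c1coc(-c2cc(-c3cccs3)nc(-c3cccs3)c2)c1` carries thiophen-2-yl in place of 2-(furan-2-yl)ethenyl on an aromatic carbon, on an aromatic carbon of a six-membered aromatic ring with 1 nitrogen, next to the ring nitrogen. For the measured compounds named here, the one step measured at that position, no change at the digits printed from compound 1 to compound 3 (within the scatter), showed nothing beyond the scatter, and compound 2, which already holds two thiophen-2-yl groups on the shared core, sits at the same figure. Going by the values given here, no measured step points to movement in this assay, so the expected step is no change at the digits printed from compound 3 to compound 4 (within the scatter), within the scatter. Compound 4 is estimated at 118000 nM, range 40000 nM to 300000 nM.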

Compound 4, half-maximal effective concentration: 118000 nM
Compound 4: middle estimate and measured number agree at the digits printed; low and high end bracket the measured number.
By their numbers in this assay, from the lowest: compounds 1, 2, 3 and 4 (each within the scatter of the next).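

Swapping 2-(furan-2-yl)ethenyl for thiophen-2-yl on the aromatic carbon next to the ring nitrogen leaves this assay flat (no change at the digits printed from compound 3 to compound 4 (within the scatter)), so losing the double bond outside aromatic rings shifts nothing here. Thiophen-2-yl in place of hydrogen at that carbon reads the same (no change at the digits printed from compound 1 to compound 4 (within the scatter)), and the furan-2-yl for pyridin-2-yl exchange at a second place on the shared core adds another flat step (no change at the digits printed from compound 2 to compound 4 (within the scatter)). No evidence on the reason for this flatness is available.

Open, on these data alone, is whether an amine or a carboxylic acid on that carbon would shift the figure.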